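Dropping the hydroxyl-bearing side chain from compound 3

The source may hold more compounds than are shown below. What is called first, only, known or untested is meant among the compounds shown, and "the series" means these compounds.

Values measured in a functional assay on BT-474 cells (Homo sapiens) for inhibition, read by MTT assay, with a stated time of 5 days; a lower number here means a stronger inhibitor, a higher number a weaker inhibitor:
Compound 1 `Cc1cc(Nc2nc(NCc3ccc(F)cc3F)nc3[nH]ncc23)n[nH]1`: 3220 nM
Compound 2 `Cc1cc(Nc2nc(NCc3ccc(F)cc3F)nc3c2cnn3C2CCOCC2)n[nH]1`: 2350 nM
Compound 3 `Cc1cc(Nc2nc(NCc3ccc(F)cc3F)nc3c2cnn3CC(C)(C)O)n[nH]1`: 19400 nM

Of these three, compound 3 has the highest number, 19400 nM, and so is the weakest inhibitor in this assay. Its gaps to the other two lie beyond the scatter: a 6.0-fold higher number from compound 1 to compound 3 (0.78 log units; beyond the scatter), and an 8.3-fold higher number from compound 2 to compound 3 (0.92 log units; beyond the scatter). By contrast, the remaining step, a 1.4-fold lower number from compound 1 to compound 2 (0.14 log units; within the scatter), lies within the scatter.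

The next compound, compound 4 `Cc1cc(Nc2nc(NCc3ccc(F)cc3F)nc3c2cnn3C2CCCCC2)n[nH]1`, carries cyclohexyl in place of 2-hydroxy-2-methylpropyl on an aromatic nitrogen. Among the compounds with values here, no compound with cyclohexyl has been measured yet, so the nearest guide is compound 2, which has oxan-4-yl at that nitrogen and gives 2350 nM. Both measured steps that introduce 2-hydroxy-2-methylpropyl raised the number, and neither compound 1 nor compound 2 goes against this. Removing that group is therefore expected to reverse a change of similar size, in the direction of a lower number. The expected change is a 7.8-fold lower number from compound 3 to compound 4 (0.89 log units; beyond the scatter), which would lie beyond the scatter. For compound 4 the estimated value is 2500 nM, with an expected range of 900 nM to 7000 nM.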

Compound 4, half-maximal inhibitory concentration: 6230 nM
For compound 4 the middle estimate is 2.5-fold (0.40 log units) below the measured one; the range from low to high includes it.
By their numbers in this assay, from the lowest: compounds 2, 1 and 4 (each within the scatter of the next, the first and the last beyond it); then compound 3.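

In this assay cyclohexyl gives back only part of what 2-hydroxy-2-methylpropyl cost at this nitrogen, with a 3.1-fold lower number from compound 3 to compound 4 (0.49 log units; beyond the scatter) as the step, and the number stays above that of compound 2. The choice between ring groups also counts here, since a 2.7-fold higher number from compound 2 to compound 4 (0.42 log units; beyond the scatter) separates cyclohexyl from oxan-4-yl, so losing the hydroxyl-bearing chain does not by itself fix the number. Yet a 1.9-fold higher number from compound 1 to compound 4 (0.29 log units; within the scatter) means that cyclohexyl cannot be told from hydrogen at this nitrogen, just as oxan-4-yl could not, which leaves 2-hydroxy-2-methylpropyl as the only one of the three groups that clearly moves the number away from that of compound 1.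

As far as these compounds go, it remains open whether the hydroxyl or the branched chain accounts for the weak result of compound 3, and how a 2-methylpropyl chain without the hydroxyl, or a piperidin-4-yl ring carrying an amine where oxan-4-yl has its oxygen, would compare. No evidence is available that bears on why these groups differ.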